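Swapping Chloro for Methyl at the Cytotoxicity Limit

The compounds below may be only part of what the source reports. "The series", "measured", "known", "first", "only" and "open" are said of these compounds alone.

In an ADME assay on MT4 cells (Homo sapiens) for cytotoxicity, read by MTT assay, with a stated time of 96 h (on this read-out higher numbers stand for lower toxicity in this test and lower numbers for higher toxicity in this test), compound 2 (`Clc1ccc(NCc2cn(-c3ccccc3)nc2-c2ccc(Cl)cc2)cc1`) gives > 100000 nM as a limit of the assay and not an exact number. Compound 1 (`FC(F)(F)c1ccc(NCc2cn(-c3ccccc3)nc2-c2ccc(Cl)cc2)cc1`) gives > 100000 nM as a limit too. Compound 2 therefore has no exact position, and the limit of > 100000 nM in this assay, at which 2 of the 2 values shown sit, is all that the data show so far.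

Compound 3 (`Cc1ccc(-c2nn(-c3ccccc3)cc2CNc2ccc(Cl)cc2)cc1`) differs from compound 2 as follows: methyl in place of chloro on an aromatic carbon turning 4-chlorophenyl to 4-methylphenyl.

Within the data shown here, only one measured step exists, and it is a step that the two limits leave unreadable from compound 1 to compound 2 with no size to carry forward. It also swaps trifluoromethyl for chloro, not the group changing here. With no measured size to build on, the estimated step is an at least 1.1-fold lower number from compound 2 to compound 3 (0.04 log units; that floor lies within the scatter) and no shift beyond the usual scatter is expected, in either direction. Another report at the limit is the likeliest outcome.

For compound 3 the estimate is 90000 nM with an expected range from 40000 nM to 100000 nM in this assay once it is measured.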

Compound 3, half-maximal cytotoxic concentration: > 100000 nM
Compound 3: a limit, no number (the forecaster's own chance of this, stated with the estimate: 75%); middle value at least 1.1-fold (0.04 log units) from the limit.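

No new step can be read: compound 2 and compound 3 both give only a limit in this assay, not an exact number, so the size of the step between them stays unknown: the limit of > 100000 nM in this assay, at which 3 of the 3 values shown sit.

The compounds shown leave open how far past that limit compound 1, compound 2 and compound 3 each lie, and whether these single swaps change the read-out at all.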